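This account rests on a few compounds, and the source may have more. Where it says the series, first, only, none or still open, it means among the compounds named here.

Measured compounds in this study:
compound 1 `Clc1ccccc1Cn1ccc2nc(-c3ccccc3)nc-2c1`
compound 2 `FC(F)(F)c1ccccc1Cn1ccc2nc(-c3ccccc3)nc-2c1`
compound 3 `CC(c1ccccc1)n1ccc2nc(-c3ccccc3)nc-2c1`

In an ADME assay on MDBK cells (Bos taurus) for cytotoxicity (on this read-out lower numbers stand for higher toxicity in this test and higher numbers for lower toxicity in this test), compound 1 gives > 100000 nM, which is a limit of the assay and not a number. Compound 2 gives > 100000 nM, likewise a limit. Compound 3 gives > 100000 nM, also a limit. Compound 1 therefore stands only at a limit, as do the other two values shown: the limit of > 100000 nM in this assay, at which 3 of the 3 values shown sit.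

Compound 4 `c1ccc(-c2nc3ccn(Cc4ccccn4)cc-3n2)cc1` differs from compound 1 by pyridin-2-yl in place of 2-chlorophenyl on a saturated chain carbon bound to an aromatic nitrogen. Within the data shown here, the one measured step, a step that the two limits leave unreadable from compound 1 to compound 2, bears on it only loosely, and its size cannot be read since both ends sit at the limit. No step beyond the scatter is therefore expected, and a number no higher from compound 1 to compound 4 (the limit leaves the size open) is estimated as none. Compound 4 is expected at 100000 nM, within 30000 nM to 300000 nM, most likely reported again as a limit.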

Compound 4, half-maximal cytotoxic concentration: > 100000 nM
Compound 4: no number, only a limit (the forecaster's own chance of this, stated with the estimate: 80%); the middle value sits exactly at the limit.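

No step can be read from compound 1 to compound 4, since both values are limits of the assay: the limit of > 100000 nM in this assay, at which 4 of the 4 values shown sit. The compounds shown leave open what number any of them would give in this assay, and whether any of these changes shifts it at all.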